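Urea and amide variations on a shared oxadiazole-azetidine core

A few compounds are considered here, and "the series" means these few. Any claim that something is new, unique, unknown or untested is made for them only; others in the source may bear on it.

Measured so far in an assay on HEK293 cells for positive allosteric modulation of metabotropic glutamate receptor 5 (Homo sapiens), read by FLIPR; a lower number here means that less compound is needed, a higher number that more compound is needed for the effect:
- compound 1 `Cc1cccc(-c2noc(C3CN(C(=O)C4CCC(C(F)(F)F)CC4)C3)n2)c1`: 1000 nM
- compound 2 `O=C(N1CCC(F)CC1)N1CC(c2nc(-c3cccc(Cl)c3)no2)C1`: 990 nM
- compound 3 `O=C(c1ccc(Cl)cc1)N1CC(c2nc(-c3cccc(F)c3)no2)C1`: 2500 nM

Compound 2 and compound 1 sit together at the low end of the three numbers; their values fall within the usual scatter of each other, so no order between them can be read. Compound 3 gives the higher number, and its gap to compound 2 lies beyond the scatter.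

The next compound, compound 4 `CC1CCN(C(=O)N2CC(c3nc(-c4cccc(Cl)c4)no3)C2)C1`, keeps the core of compound 2 and changes only the ring attached to the carbonyl carbon: 3-methylpyrrolidin-1-yl in place of 4-fluoropiperidin-1-yl on a carbonyl carbon. Both groups carry no hydrogen-bond donors or acceptors and no net charge; the ring shrinks from six members to five and the fluorine gives way to a methyl.

Among the compounds with values here, no measured pair in the set shows this kind of exchange, so there is nothing to anchor the size of the step. The expectation is no movement beyond the scatter in this assay, so the step from compound 2 to compound 4 is estimated at a 1.2-fold higher number from compound 2 to compound 4 (0.08 log units; within the scatter). Compound 4 is therefore expected to give about 1200 nM, within a range from 500 nM to 3000 nM.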

Compound 4, half-maximal effective concentration: > 10000 nM
Compound 4: only a limit was reported (the forecaster's own chance of this, stated with the estimate: 5%); middle value at least 8.3-fold (0.92 log units) away from the limit.
By their numbers in this assay, from the lowest: compounds 2 and 1 (each within the scatter of the next); then compound 3. At a limit, above all of these: compound 4.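

In this assay, compound 4 gives > 10000 nM, which is a limit of the assay and not a number. Within the data shown here, the exchange of the ring on the carbonyl carbon gives an at least 10-fold higher number from compound 2 to compound 4 (1.00 log units; beyond the scatter), the first single-place exchange and the first sign that the ring at this position can shift the read-out beyond the scatter. The true size of this step remains unresolved, and it is bounded on one side only: the limit of > 10000 nM in this assay, at which 1 of the 4 values shown sits.

Ring size and the exchange of fluorine for methyl change together here, and the compounds shown do not separate them. Going by these compounds, how plain pyrrolidin-1-yl, 4-methylpiperidin-1-yl or morpholin-4-yl would behave on the same carbonyl carbon stays open.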